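Shortening the amide linker in a purine-based hybrid

The source may report more compounds than this note shows. Statements on the series, on what has been measured and on what is new or still open speak of the compounds shown alone.

Of the compounds shown here, two have so far been tested in a functional assay on HCT-116 cells (Homo sapiens) for antiproliferative activity, read by CCK-8 assay, with a stated time of 72 h, tested at 2 uM; a lower number here means a weaker effect, a higher number a stronger effect of the compound at the concentration tested. Compound 1 `CC(C)n1cnc2c(Nc3ccccc3)nc(NCOCc3ccc(C(=O)Nc4ccccc4N)cc3)nc21` gives 6.85% in this assay. Compound 2 `CCCCn1cnc2c(Nc3ccccc3)nc(NCOCc3ccc(/C=C/C(=O)Nc4ccccc4N)cc3)nc21` gives 6.58% in this assay, which is the lowest of the two numbers, but only by a margin that lies within the usual scatter of such measurements, so the two compounds cannot be told apart on these numbers. Both values are small, meaning that at the tested concentration neither compound holds back the growth of the cells to any great extent.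

Compound 3 `CCCCn1cnc2c(Nc3ccccc3)nc(NCOCc3ccc(C(=O)Nc4ccccc4N)cc3)nc21` has not yet been measured. It differs from compound 2 in one place: (2-aminophenyl)carbamoyl in place of 2-((2-aminophenyl)carbamoyl)ethenyl on an aromatic carbon. Compound 1 already carries the (2-aminophenyl)carbamoyl group that enters here, and its value lies within the scatter of that of compound 2. Among the measured compounds shown here, no measured pair shows this particular change on its own, so the expectation rests on those two numbers alone. The expected step in this assay is none beyond the scatter, a number 0.4 percentage points higher from compound 2 to compound 3 (within the scatter). Compound 3 is therefore estimated to give 7% in this assay, with a range from 1% to 15%.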

Compound 3, a percentage reported as inhibition, at one concentration (the size of the read-out at that concentration, not a potency): 72.9%
For compound 3 the middle estimate is 65.9 percentage points below the measured one; measured number outside the range, above it.
By their numbers in this assay, from the lowest: compounds 2 and 1 (each within the scatter of the next); then compound 3.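

In this assay, the group on the aromatic carbon, para to a large group, turns out to matter greatly: with butyl on the aromatic nitrogen, putting (2-aminophenyl)carbamoyl in place of 2-((2-aminophenyl)carbamoyl)ethenyl gives a number 66.3 percentage points higher from compound 2 to compound 3 (beyond the scatter) and changes a near-silent compound into one with a clear effect at the tested concentration. The group on the aromatic nitrogen matters just as much, since with (2-aminophenyl)carbamoyl held constant, butyl in place of isopropyl gives a number 66.1 percentage points higher from compound 1 to compound 3 (beyond the scatter) as well. Of these compounds, only compound 3 carries both butyl and (2-aminophenyl)carbamoyl, so the two earlier low numbers, which looked alike, gave no sign that this combination would stand so far apart.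

The compounds shown leave open whether a propyl or pentyl chain on that nitrogen would serve as butyl does, and whether 2-((2-aminophenyl)carbamoyl)ethyl, the same chain without its carbon-carbon double bond, would behave like the ethenyl group. Nothing at hand accounts for the size of either step.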